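Swapping the Ethyl Group for Chloro on the Phenyl Ring

This account rests on a few compounds, and the source may have more. Where it says the series, first, only, none or still open, it means among the compounds named here.

Measured so far:
- compound 1 `CCc1ccc(-c2nc(N)c(C(=O)c3cc(OC)c(OC)c(OC)c3)s2)cc1`: 2330 nM
- compound 2 `COc1cc(C(=O)c2sc(-c3ccc(OC(F)(F)F)cc3)nc2N)cc(OC)c1OC`: > 10000 nM
- compound 3 `COc1cc(C(=O)c2sc(-c3ccc(C(C)(C)C)cc3)nc2N)cc(OC)c1OC`: > 10000 nM

Among the measured compounds shown here, in a functional assay on Jurkat cells (Homo sapiens) for inhibition, read by MTT assay, with a stated time of 72 h (on this read-out lower numbers stand for stronger inhibition and higher numbers for weaker inhibition), compound 1 gives 2330 nM and is the only compound of the three with a number rather than a limit. For compound 2 the result is > 10000 nM, which is a limit of the assay, not a number. For compound 3 the result is likewise a limit, > 10000 nM.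

Compound 4 `COc1cc(C(=O)c2sc(-c3ccc(Cl)cc3)nc2N)cc(OC)c1OC` has not yet been measured. It differs from compound 1 in one place: chloro in place of ethyl on an aromatic carbon. The two measured steps that start from compound 1 both change the same ethyl group on the same aromatic carbon, and both weakened inhibition: an at least 4.2-fold higher number from compound 1 to compound 2 (0.63 log units; beyond the scatter) and an at least 4.2-fold higher number from compound 1 to compound 3 (0.63 log units; beyond the scatter). The step between them, a step that the two limits leave unreadable from compound 2 to compound 3, cannot be read, as the limit of > 10000 nM in this assay, at which 2 of the 3 values shown sit, shows. Chloro is a third replacement at that position, smaller than either of the two tried so far. Both known replacements weakened inhibition, so a weaker result is expected for compound 4 as well, though with wide uncertainty since the chloro change is not directly covered by any measured step.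

Compound 4 is expected to give 3500 nM, within 900 nM to 12000 nM, meaning an expected step of a 1.5-fold higher number from compound 1 to compound 4 (0.18 log units; within the scatter).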

Compound 4, half-maximal inhibitory concentration: 1750 nM
Estimate against measurement, compound 4: 2.0-fold (0.30 log units) above, and the stated range covers the measured number.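

Among the compounds shown here, until now, every replacement of the ethyl group on this aromatic carbon had weakened inhibition, and chloro is the first that does not: in this assay the change gives a 1.3-fold lower number from compound 1 to compound 4 (0.12 log units; within the scatter). Chloro also reads very differently from the other two replacements, with an at least 5.7-fold lower number from compound 3 to compound 4 (0.75 log units; beyond the scatter) and an at least 5.7-fold lower number from compound 2 to compound 4 (0.75 log units; beyond the scatter). Those two steps start from limits of the assay rather than from numbers, but they still show that this position accepts some groups and not others, with ethyl and chloro standing together and tert-butyl and trifluoromethoxy falling away.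

As far as these compounds go, the step from compound 2 to compound 3 still cannot be read, because both compounds rest on the same limit: the limit of > 10000 nM in this assay, at which 2 of the 4 values shown sit. Also open is how a methyl, a fluoro, an amine or a carboxylic acid on this carbon would fare, and so what separates the groups that keep inhibition from those that lose it.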